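Tolerance of a Fluorophenyl Analogue in Bovine Kidney Cells

The source may report more compounds than this note shows. Statements on the series, on what has been measured and on what is new or still open speak of the compounds shown alone.

Two compounds have been measured in an ADME assay on MDBK cells (Bos taurus) for cytotoxicity, read by MTT assay, with a stated time of 96 h; a lower number here means that less compound is tolerated, a higher number that more compound is tolerated:

Compound 1 `FC(F)(F)c1cccc(NC(=S)Nc2ccc(Cl)cc2)c1` gives 17000 nM.
Compound 2 `CCCCc1ccc(NC(=S)Nc2cccc(C(F)(F)F)c2)c(C)c1` gives 10000 nM.

Compound 1 has the higher of the two numbers, but compound 2 lies within the scatter of it, so the two cannot be ranked against each other. Compound 3 `Fc1ccccc1NC(=S)Nc1cccc(C(F)(F)F)c1` has not yet been measured. It differs from compound 1 in one place: 2-fluorophenyl in place of 4-chlorophenyl on an amide-type nitrogen. Among the measured compounds shown here, no pair of measured compounds shows what such a swap does in this assay, so the expectation rests on the shared core and the two values alone. The change is expected to move the number little, if at all: a step for compound 3 of about a 1.2-fold higher number from compound 1 to compound 3 (0.07 log units; within the scatter) in this assay, which stays inside the scatter. Compound 3 is therefore estimated at 20000 nM, with a range from 8000 nM to 50000 nM.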

Compound 3, half-maximal cytotoxic concentration: > 100000 nM
Compound 3: only a limit was reported; the forecaster's own chance of this, stated with the estimate: 15%; middle value at least 5.0-fold (0.69 log units) away from the limit.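

In this assay the swap of 4-chlorophenyl for 2-fluorophenyl on the amide-type nitrogen gives an at least 5.8-fold higher number from compound 1 to compound 3 (0.76 log units; beyond the scatter) even though the two groups have the same count of heavy atoms. Compound 3 gives > 100000 nM as its reading, and this is a limit of the assay, not a number. The group at this place on the shared core therefore matters for how much compound the cells tolerate, which compound 1 and compound 2 could not show, since they differ in more than one place.

One swap cannot tell whether the chlorine, the fluorine or the place of the halogen on the ring matters most, and a plain phenyl group at the same nitrogen would be a first test of this. The true size of the step also stays unknown, because the value of compound 3 sits at the top of what was read: the limit of > 100000 nM in this assay, at which 1 of the 3 values shown sits.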